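Swapping an allyl for an acetyl on a xanthine

The source may report more compounds than this note shows. Statements on the series, on what has been measured and on what is new or still open speak of the compounds shown alone.

Of the compounds shown here, two have been measured in a functional assay (trachea) with Cavia porcellus as the target; on this read-out higher numbers stand for an effect only at larger amounts of compound and lower numbers for an effect already at smaller amounts. Compound 1 `CCCn1c(=O)n(CCCO)c(=O)c2[nH]cnc21` gives 5100 nM. Compound 2 `C=CCCn1cnc2c1c(=O)n(C)c(=O)n2CCC` gives 16800 nM, the higher of the two numbers, beyond the usual scatter from compound 1. Compound 3 `CCCn1c(=O)n(C)c(=O)c2c1ncn2CC(C)=O` is not yet measured; it differs from compound 2 by acetyl in place of allyl on a saturated chain carbon bound to an aromatic nitrogen. Among the measured compounds shown here, with no comparable step among the measured pairs, a step from compound 2 to compound 3 of a 1.4-fold lower number from compound 2 to compound 3 (0.15 log units; within the scatter) is expected, downward but hardly beyond the scatter. Compound 3 is therefore estimated at 12000 nM, within 4000 nM to 40000 nM in this assay.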

Compound 3, half-maximal effective concentration: 1900 nM
Beside the measured number, compound 3's estimate is 6.3-fold (0.80 log units) above it; measured number below the stated range.
By their numbers in this assay, from the lowest: compound 3; then compound 1; then compound 2.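

In this assay, acetyl in place of allyl on a saturated chain carbon bound to an aromatic nitrogen gives an 8.8-fold lower number from compound 2 to compound 3 (0.95 log units; beyond the scatter), so the read-out responds clearly to a change at this position. The two groups are the same size in heavy atoms, yet acetyl brings an oxygen and a hydrogen-bond acceptor where allyl has neither. Nothing available explains why the number falls.

The compounds shown leave open whether the oxygen itself matters. They also leave open how an amine, a carboxylic acid or a longer chain would fare at this position.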